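This account rests on a few compounds, and the source may have more. Where it says the series, first, only, none or still open, it means among the compounds named here.

Of the compounds shown here, three built on one shared core have so far been tested in an assay on isolated protein for inhibition of leukotriene B4 receptor 1 (Homo sapiens), tested at 10 uM; on this read-out lower numbers stand for less inhibition and higher numbers for more inhibition at the one concentration tested (going by the name of the read-out). Compound 1 `CCCCCCc1cc(C(C)=O)c(O)cc1OCCCCC#N` gives 51% in this assay, compound 2 `COCc1cc(C(C)=O)c(O)cc1OCCCCCCC#N` gives 47%, and compound 3 `CCc1cc(C(C)=O)c(O)cc1OCCCCCCCC(C)(C)C#N` gives 66%. On these numbers compound 3 stands highest of the three: the nearest number is that of compound 1, which lies lower by a margin beyond the usual scatter, and the furthest is that of compound 2, which lies lower still, again beyond the scatter. Compound 3 therefore gives the highest number of the three as measured.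

Compound 4 `CCc1cc(C(C)=O)c(O)cc1OCCCCCC[S+](C)[O-]` has not yet been measured. It differs from compound 3 in a single place: a group of 3 heavy atoms (1 carbon, 1 oxygen, 1 sulfur; no ring) in place of a group of 6 heavy atoms (5 carbon, 1 nitrogen; no ring), on a saturated chain carbon, six bonds along the chain from an oxygen on an aromatic ring. In words, the end of the chain that carries the nitrile in compound 3 is exchanged for a smaller group that holds a sulfur and an oxygen and no nitrile at all.

Among the compounds with values here, no pair of measured compounds differs in just one place, so there is no measured step to lean on. The expectation for compound 4 is a moderate fall in this assay, since the highest number belongs to compound 3 with 66% and the change removes the group that compound 3 alone carries. Compound 4 is expected to give about 45% in this assay, within a range from 22% to 66%. This estimate corresponds to an expected step of a number 21 percentage points lower from compound 3 to compound 4 (beyond the scatter), somewhat beyond the scatter in the downward direction.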

Compound 4, a percentage reported as inhibition, at one concentration (the size of the read-out at that concentration, not a potency): 92%
Compound 4: middle estimate off by 47 percentage points, on the low side; the measured number lies above the stated range.
By their numbers in this assay, from the lowest: compounds 2 and 1 (each within the scatter of the next); then compound 3; then compound 4.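

In this assay, the change on a saturated chain carbon, six bonds along the chain from an oxygen on an aromatic ring, brings a number 26 percentage points higher from compound 3 to compound 4 (beyond the scatter) when the 2-cyano-2-methylpropyl group leaves and the smaller group holding a sulfur and an oxygen enters. Within the data shown here, every earlier compound carried a nitrile, so only this step shows that a high number at the one concentration tested does not need a nitrile at this end of the chain, and that a group with fewer heavy atoms can give the higher number here. Nothing measured here explains the rise.

Among these compounds, the single step swaps both groups at once, leaving it open whether the rise comes from losing the 2-cyano-2-methylpropyl group or from gaining the group with sulfur and oxygen. Also open, as far as these compounds go, is how a carboxylic acid, an amine or a longer chain ending in the same sulfur and oxygen group would fare at this place, and how the compounds compare in potency, as the read-out is a percentage at a single concentration.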